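Adding a Chlorine: Estimating Compound 4 Before Measurement

A few compounds are considered here, and "the series" means these few. Any claim that something is new, unique, unknown or untested is made for them only; others in the source may bear on it.

Compound 2 `ClCc1ccccc1Cn1cnc2c(Cl)ncnc21` and compound 1 `ClCc1ccccc1Cn1cnc2c(Cl)nc(Cl)nc21` share a core and differ in one change, (chloro in place of hydrogen on an aromatic carbon). In a functional assay on NCI/ADR-RES cells (Homo sapiens) for cytotoxicity, read by sulforhodamine B assay, with a stated time of 48 h (on this read-out lower numbers stand for stronger inhibition of growth and higher numbers for weaker inhibition of growth), compound 2 gives 4670 nM, and compound 1 gives 3020 nM, so the step is a 1.5-fold lower number from compound 2 to compound 1 (0.19 log units; within the scatter). Compound 3 `ClCc1cccc(Cn2cnc3c(Cl)ncnc32)c1` has the same atoms as compound 2 joined differently; the difference between the two cores is not broken down here. In this assay compound 3 gives 7580 nM. Compound 4 `ClCc1cccc(Cn2cnc3c(Cl)nc(Cl)nc32)c1` differs from compound 3 by the same change, (chloro in place of hydrogen on an aromatic carbon), with the surroundings of the place described in the same words. The step from compound 3 to compound 4 is estimated at a 1.5-fold lower number from compound 3 to compound 4 (0.16 log units; within the scatter), because the earlier step of a 1.5-fold lower number from compound 2 to compound 1 (0.19 log units; within the scatter) was small. Compound 4 is therefore expected to give about 5200 nM in this assay, with a likely range from 2600 nM to 10400 nM.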

Compound 4, concentration for total growth inhibition: 5240 nM
Beside the measured number, compound 4's estimate is 1.0-fold (0.00 log units) below it; measured number inside the range.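

In this assay the new step is a 1.4-fold lower number from compound 3 to compound 4 (0.16 log units; within the scatter). Set beside the earlier step, the same change behaves alike on the two cores: the same change on two cores in this assay, a 1.5-fold lower number (0.19 log units; within the scatter) from compound 2 to compound 1 and a 1.4-fold lower number (0.16 log units; within the scatter) from compound 3 to compound 4, 1.1-fold (0.03 log units) apart, within the scatter of two such steps. Among the compounds shown here, both steps lie within the scatter, so this shows only that adding the chloro group made no clear difference on either core; it does not show that the group has a real effect of its own, or that the match would hold on a core outside these four compounds.

The compounds shown leave open what a different group, such as an amine or a methoxy group, would do on the aromatic carbon between two ring nitrogen atoms. Going by these compounds, whether any such group would produce a step beyond the scatter also remains open.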